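A few compounds are considered here, and "the series" means these few. Any claim that something is new, unique, unknown or untested is made for them only; others in the source may bear on it.

Measured compounds:
compound 1 `c1coc(-c2ccnc(-c3cccs3)c2)c1` gives 118000 nM
compound 2 `c1ccc(-c2cc(-c3cccs3)nc(-c3cccs3)c2)nc1` gives 118000 nM
compound 3 `c1ccc(-c2cc(-c3ccco3)ccn2)nc1` gives 118000 nM

All three were tested in a functional assay on HCT-15 cells (Homo sapiens) for antiproliferative activity; on this read-out higher numbers stand for an effect only at larger amounts of compound and lower numbers for an effect already at smaller amounts. At the digits shown, compound 2 is level with compound 1 and with compound 3, so none of the three can be called more or less active than the others; the spread among them lies within the scatter.

Compound 4 `c1coc(-c2cc(-c3cccs3)nc(-c3cccs3)c2)c1` has not been measured. It differs from compound 2 in one place: furan-2-yl in place of pyridin-2-yl on an aromatic carbon. Going by the values given here, no measured pair in this set isolates such a swap, so the data give no step to lean on.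

With all three measured compounds sitting at the same reading, compound 4 is expected to land at about the same level, with a step of no change at the digits printed from compound 2 to compound 4 (within the scatter) that stays within the scatter. The estimate for compound 4 is 118000 nM, within 60000 nM to 150000 nM.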

Compound 4, half-maximal effective concentration: 118000 nM
For compound 4 middle estimate and measured number coincide at the digits printed, within the range that was stated.
By their numbers in this assay, from the lowest: compounds 1, 2, 3 and 4 (each within the scatter of the next).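

In this assay furan-2-yl in place of pyridin-2-yl, opposite the ring nitrogen, gives no change at the digits printed from compound 2 to compound 4 (within the scatter) and so this position reads the same with either ring. Thiophen-2-yl in place of hydrogen on an aromatic carbon gives no change at the digits printed from compound 1 to compound 4 (within the scatter) as well, so this added ring shifts nothing either. Nothing available explains these results.

As far as these compounds go, all four compounds carry only aromatic rings at these places, so whether an amine or a carboxylic acid here would move the reading stays open. With every reading level, the compounds shown reveal no change that lowers the number.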